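Trimming the tetrazole substituent of compound 3

The compounds below may be only part of what the source reports. "The series", "measured", "known", "first", "only" and "open" are said of these compounds alone.

Among the compounds with values here, in a functional assay (Pituitary gland cell) with Rattus norvegicus as the target (a lower number here means that less compound is needed, a higher number that more compound is needed for the effect), compound 3 `CC(O)Cn1nnnc1-c1ccccc1-c1ccc(CN2C(=O)[C@H](NC(=O)CC(C)(C)N)CCc3ccccc32)cc1` gives 0.05 uM, the lowest of the three numbers known. Its nearest neighbour is compound 1 `Cc1ccccc1-c1ccc(CN2C(=O)[C@H](NC(=O)CC(C)(C)N)CCc3ccccc32)cc1`, which in this assay gives 1 uM, and the furthest is compound 2 `CC(C)(N)CC(=O)N[C@@H]1CCc2ccccc2N(Cc2ccc(-c3ccccc3S(N)(=O)=O)cc2)C1=O` with 3 uM. The measured steps all sit on one aromatic carbon: a 3.0-fold higher number from compound 1 to compound 2 (0.48 log units; beyond the scatter), a 20-fold lower number from compound 1 to compound 3 (1.30 log units; beyond the scatter) and a 60-fold lower number from compound 2 to compound 3 (1.78 log units; beyond the scatter). Compound 4 `Cn1nnnc1-c1ccccc1-c1ccc(CN2C(=O)[C@H](NC(=O)CC(C)(C)N)CCc3ccccc32)cc1` is not yet measured in this assay. It differs from compound 3 in one place: hydrogen in place of 1-hydroxyethyl on a saturated chain carbon bound to an aromatic nitrogen. None of the three measured steps touches this position; they all exchange the whole group on the aromatic carbon, and the 1-(2-hydroxypropyl)-1H-tetrazol-5-yl group as a whole went with the large gains seen from compound 1 and compound 2. The change to compound 4 keeps the tetrazole ring and removes only the 1-hydroxyethyl part, so a step far smaller than those measured is expected, most likely a small loss or none beyond the scatter. Compound 4 is therefore estimated at 0.1 uM, within 0.03 uM to 0.4 uM, which means an expected step of a 2.0-fold higher number from compound 3 to compound 4 (0.30 log units; within the scatter).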

Compound 4, concentration for half-maximal effect: 0.5 uM
Compound 4: the middle estimate sits 5.0-fold (0.70 log units) below what was measured, and the stated range ends below it.
By their numbers in this assay, from the lowest: compound 3; then compounds 4 and 1 (each within the scatter of the next); then compound 2.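

In this assay, within the data shown here, the result divides the large gain that the earlier compounds could only credit to the 1-(2-hydroxypropyl)-1H-tetrazol-5-yl group as a whole: removing just the 1-hydroxyethyl part from the saturated chain carbon bound to an aromatic nitrogen gives a 10-fold higher number from compound 3 to compound 4 (1.00 log units; beyond the scatter), so this small part of the group carries real weight. The 1-methyl-1H-tetrazol-5-yl group still stands apart from sulfamoyl, with a 6.0-fold lower number from compound 2 to compound 4 (0.78 log units; beyond the scatter), but exchanging methyl for it gives a 2.0-fold lower number from compound 1 to compound 4 (0.30 log units; within the scatter), so the tetrazole bearing only a methyl does not separate from the methyl compound, and the distance of compound 3 from compound 1 depends on the 2-hydroxypropyl chain. Nothing available explains this step.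

Compound 3 and compound 4 differ in both the hydroxyl and the chain carbons, so the compounds shown do not tell the two apart: a plain propyl chain would keep the carbons without the hydroxyl, and a 2-hydroxyethyl chain would keep the hydroxyl on a shorter chain. Going by these compounds, whether an amine or a carboxylic acid on that chain could stand in for the hydroxyl also stays open.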